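The compounds below may be only part of what the source reports. "The series", "measured", "known", "first", "only" and "open" are said of these compounds alone.

Measured compounds:
Compound 1 `O=C(/C=C/c1ccccc1)c1ccc(N2CCN(c3ccc([N+](=O)[O-])cc3)CC2)cc1` — in a functional assay on the whole organism (strain Kunming) for inhibition, with Mus musculus as the target, with a stated time of 1 h, at a dose of 40 mg/kg by the oral route (a higher number here means more inhibition at the dose given (going by the name of the read-out), a lower number less inhibition), compound 1 gives 55.4%
Compound 2 `O=C(/C=C/c1ccccc1)c1ccc(N2CCN(c3ccccc3Cl)CC2)cc1` — compound 2 gives 4.71%
Compound 3 `O=C(/C=C/c1ccccc1)c1ccc(N2CCN(c3ccccc3)CC2)cc1` — compound 3 gives 3.71%

Compound 3 stands lowest of the three in this assay. Compound 2 lies nearest to it, with a number 1 percentage points lower from compound 2 to compound 3 (within the scatter) inside the scatter, while compound 1 stands far higher, with a number 51.7 percentage points lower from compound 1 to compound 3 (beyond the scatter). Compound 4 `O=C(/C=C/c1ccccc1)c1ccc(N2CCN(S(=O)(=O)c3ccccc3)CC2)cc1` differs from compound 3 in one place: phenylsulfonyl in place of phenyl on an amine nitrogen in a ring. Going by the values given here, no measured step exchanges a group of this kind on that ring nitrogen. The steps seen there are a number 50.7 percentage points lower from compound 1 to compound 2 (beyond the scatter), which was large, and a number 1 percentage points lower from compound 2 to compound 3 (within the scatter), which was not, so a change at this nitrogen has been both large and negligible. Among the compounds with values here, no direct analogue exists. Compound 4 is therefore estimated at 20%, within 3% to 50%. The expected step is a number 16.3 percentage points higher from compound 3 to compound 4 (beyond the scatter), upward but uncertain.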

Compound 4, a percentage reported as inhibition, in the whole organism at one dose (the size of the read-out at that dose, not a potency): 30%
Compound 4: middle estimate off by 10 percentage points, on the low side; the measured number falls inside the stated range.
By their numbers in this assay, from the lowest: compounds 3 and 2 (each within the scatter of the next); then compound 4; then compound 1.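

In this assay, a group other than 4-nitrophenyl also raises the read-out at this ring nitrogen, with a number 26.3 percentage points higher from compound 3 to compound 4 (beyond the scatter) and a number 25.3 percentage points higher from compound 2 to compound 4 (beyond the scatter). The phenylsulfonyl group still does not match 4-nitrophenyl, with a number 25.4 percentage points lower from compound 1 to compound 4 (beyond the scatter), so the nitrogen's substituents now span three separate levels rather than two. Nothing available explains these differences.

As far as these compounds go, it remains open whether the gain depends on the sulfonyl link or on the phenyl attached to it. A methanesulfonyl or benzoyl group on that nitrogen would help to separate the two.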